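The source may hold more compounds than are shown below. What is called first, only, known or untested is meant among the compounds shown, and "the series" means these compounds.

Compound 1 `COc1ccc(CNCCCNS(=O)(=O)c2cc(C(F)(F)F)cc(C(F)(F)F)c2)cc1OC`: 6400 nM
Compound 2 `CN(CCCNS(=O)(=O)c1cc(C(F)(F)F)cc(C(F)(F)F)c1)Cc1ccccc1`: 51000 nM

In a functional assay on ASPC1 cells (Homo sapiens) for inhibition, read by MTT assay, with a stated time of 72 h (a higher number here means a weaker inhibitor of growth, a lower number a stronger inhibitor of growth), compound 2 gives the higher of the two numbers, 51000 nM, while compound 1 gives 6400 nM, a gap beyond the scatter. Compound 3 `COc1ccccc1CNCCCNS(=O)(=O)c1cc(C(F)(F)F)cc(C(F)(F)F)c1` differs from compound 2 by (2-methoxybenzyl)amino in place of benzyl(methyl)amino on a saturated chain carbon, three bonds along the chain from a sulfonamide nitrogen. Going by the values given here, no measured pair shows this exact change, so its size is uncertain, but a move toward a lower number seems likely because compound 1 with its free amine and methoxy groups gives 6400 nM. The step of a 4.3-fold lower number from compound 2 to compound 3 (0.63 log units; beyond the scatter) is expected. Compound 3 is therefore expected to give 12000 nM, in the range 4000 nM to 40000 nM.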

Compound 3, concentration for 50% growth inhibition: 4600 nM
Beside the measured number, compound 3's estimate is 2.6-fold (0.42 log units) above it; the measured number falls inside the stated range.
By their numbers in this assay, from the lowest: compounds 3 and 1 (each within the scatter of the next); then compound 2.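

In this assay, (2-methoxybenzyl)amino in place of benzyl(methyl)amino gives an 11-fold lower number from compound 2 to compound 3 (1.04 log units; beyond the scatter), so a change at this saturated chain carbon can shift the number strongly. Moving from 3,4-dimethoxyphenyl to 2-methoxyphenyl gives a 1.4-fold lower number from compound 1 to compound 3 (0.14 log units; within the scatter), so these two rings cannot be told apart in this assay.

Still open, from the compounds shown here alone, is whether the large step follows the loss of the methyl on the amine nitrogen or the gain of the ring methoxy, and a plain benzylamino group would help separate the two. Nothing measured here gives a reason for either step.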